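From nitro to 2-methoxyethoxy on a shared core

The source may hold more compounds than are shown below. What is called first, only, known or untested is meant among the compounds shown, and "the series" means these compounds.

Compounds measured in an ADME assay on BJ cells (Homo sapiens) for cytotoxicity, with a stated time of 72 h (a higher number here means that more compound is needed for the effect, a lower number that less compound is needed), so far
compound 1 `COc1cc2ncnc(-n3nc(-c4ccccn4)nc3N)c2cc1[N+](=O)[O-]` gives > 13000 nM
compound 2 `Nc1nc(-c2ccccn2)nn1-c1ncnc2cc(N3CCNCC3)c([N+](=O)[O-])cc12` gives "not determined" (no result reported)
compound 3 `COc1cc2ncnc(-n3cnc(-c4ccccn4)n3)c2cc1OC` gives > 27000 nM

Compound 1 stands at > 13000 nM in this assay and this entry is a limit of the assay, not a number. Compound 3 gives > 27000 nM and this entry is likewise a limit. Compound 2 has no result, so none of the three compounds offers a single measured number.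

Compound 4 `COCCOc1cc2c(-n3nc(-c4ccccn4)nc3N)ncnc2cc1OC` is still to be measured. It carries 2-methoxyethoxy in place of nitro on an aromatic carbon and that carbon is ortho to a methoxy group. For the measured compounds named here, no measured pair of compounds shows what a single change does here, so the expectation rests on the limits alone. It leans first on compound 1 with its limit of > 13000 nM in this reading. It leans also on compound 3 with its limit of > 27000 nM in the same assay. The estimated step that the limit leaves unreadable from compound 1 to compound 4 is therefore expected to stay within the usual scatter of this assay with no clear direction, and another limit is the likeliest report. Compound 4 is estimated at 20000 nM with an expected range from 9000 nM to 40000 nM in this assay.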

Compound 4, half-maximal effective concentration: > 13000 nM
Compound 4 gave a limit, no number (the forecaster's own chance of this, stated with the estimate: 70%); the middle value lies beyond the limit too.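

In this assay compound 4 gives > 13000 nM, which is a limit of the assay and not a number. Compound 1 gives > 13000 nM, which is also a limit. For the compounds shown here, no step from compound 1 to compound 4 can be read from these two entries. The compounds shown leave open what 2-methoxyethoxy in place of nitro does to the half-maximal effective concentration.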